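The source may report more compounds than this note shows. Statements on the series, on what has been measured and on what is new or still open speak of the compounds shown alone.

Values so far in an ADME assay on microsomes from liver (Mus musculus, strain CD-1) for metabolic stability, read by LC-MS, tested at 2 uM; on this read-out lower numbers stand for a shorter-lived compound and higher numbers for a longer-lived compound
compound 1 `Cn1ccc2ccc(-c3cc(Nc4cnccc4C(=O)NCc4cncnc4)cc4nccnc34)cc21` gives 0.4 h
compound 2 `CN1CCC(NC(=O)c2ccncc2Nc2cc(-c3ccc4ccn(C)c4c3)c3nccnc3c2)CC1` gives > 1 h
compound 3 `CN1CC(NC(=O)c2ccncc2Nc2cc(-c3ccc4ccn(C)c4c3)c3nccnc3c2)C1` gives > 1 h

Compound 3 reads > 1 h and this is a limit, not a number. Compound 2 reads > 1 h and this too is a limit. Compound 3 sits at the limit of > 1 h in this assay, at which 2 of the 3 values shown sit, and so has no exact place in the series.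

The next structure is compound 4 `CN1CCC(CNC(=O)c2ccncc2Nc2cc(-c3ccc4ccn(C)c4c3)c3nccnc3c2)C1` with the change (1-methylpyrrolidin-3-yl)methyl in place of 1-methylazetidin-3-yl on an amide-type nitrogen in which (1-methylpyrrolidin-3-yl)methyl takes the place of 1-methylazetidin-3-yl on an amide-type nitrogen.

Going by the values given here, two measured steps bear on this. Both an at least 2.5-fold higher number from compound 1 to compound 2 (0.39 log units; beyond the scatter) and an at least 2.5-fold higher number from compound 1 to compound 3 (0.39 log units; beyond the scatter) lie beyond the scatter and are at least modest, and each replaces (pyrimidin-5-yl)methyl with a non-aromatic ring group. The entering group in compound 4 is also a non-aromatic ring group, though it keeps a methyl link like the group in compound 1. The remaining step, a step that the two limits leave unreadable from compound 2 to compound 3, cannot be sized, so the effect of changing between such ring groups remains unmeasured. No step beyond the scatter is therefore expected, and the estimated step is a number no higher from compound 3 to compound 4 (the limit leaves the size open) in this assay with another report as a limit quite possible. The estimate for compound 4 is 1 h with an expected range of 0.5 h to 2 h in this assay as the read-out.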

Compound 4, half-life: > 1 h
Compound 4 ended at the assay's limit (the forecaster's own chance of this, stated with the estimate: 55%); the middle value lies on the limit itself.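

In this assay compound 4 reads > 1 h, and this is a limit of the assay, not a number. Keeping the methyl link on the amide-type nitrogen and changing only the ring group, from pyrimidin-5-yl to 1-methylpyrrolidin-3-yl, gives an at least 2.5-fold higher number from compound 1 to compound 4 (0.39 log units; beyond the scatter), so the short half-life does not follow the link alone, which the earlier steps, with the link removed along with the ring group, could not show. The steps from compound 3 to compound 4 and from compound 2 to compound 4 cannot be read, and compound 2, compound 3 and compound 4 stay unranked, all held at a single mark: the limit of > 1 h in this assay, at which 3 of the 4 values shown sit.

Going by these compounds, how far the half-lives of compound 2, compound 3 and compound 4 run past that limit stays open, and with it any order among the azetidine, pyrrolidine and piperidine groups. Also open, on these data alone, is whether the ring is needed at all, as an open-chain dimethylaminoethyl group on the amide-type nitrogen would test, and whether a tetrahydropyran-4-yl group, with oxygen in place of the ring nitrogen, would read the same in this assay.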